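Aryl for methyl on the ring amine nitrogen: compound 4

The source may report more compounds than this note shows. Statements on the series, on what has been measured and on what is new or still open speak of the compounds shown alone.

Compound 1 `CCCn1c(=O)[nH]c2nc(-c3ccc(S(=O)(=O)N4CCN(C)CC4)cc3)[nH]c2c1=O` carries a methyl on an amine nitrogen in a ring. Within the data shown here, in an assay on CHO cells for displacement of a labelled ligand from adenosine receptor A2b (Homo sapiens), read by scintillation counting, with a stated time of 75 min, in the presence of a further agent that is not named here (on this read-out higher numbers stand for weaker inhibition and lower numbers for stronger inhibition), compound 1 gives 48.2 nM, the highest of the three numbers measured so far. Compound 3 `CCCn1c(=O)c2[nH]c(-c3ccc(S(=O)(=O)N4CCN(c5ccc(Cl)cc5)CC4)cc3)nc2n(C)c1=O` gives 1.91 nM; it is the nearest to compound 1, yet its number lies beyond the scatter below it. Among the measured compounds shown here, compound 2 `CCCn1c(=O)[nH]c2nc(-c3ccc(S(=O)(=O)N4CCN(c5ccccc5Br)CC4)cc3)[nH]c2c1=O` gives 0.137 nM, the lowest of the three, and it is the only measured compound that differs from compound 1 in a single place: a 350-fold lower number from compound 1 to compound 2 (2.55 log units; beyond the scatter).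

Compound 4 `CCCn1c(=O)[nH]c2nc(-c3ccc(S(=O)(=O)N4CCN(c5ccc(I)cc5)CC4)cc3)[nH]c2c1=O` is the next member of the series. It differs from compound 1 as follows: 4-iodophenyl in place of methyl on an amine nitrogen in a ring. For the measured compounds named here, the one measured step that bears on this change is the move from compound 1 to compound 2, where an aryl group likewise replaced the methyl on the ring amine nitrogen and the number fell by a large margin. Compound 3, which bears a 4-chlorophenyl on the same ring nitrogen but also differs from compound 1 elsewhere, offers only its value for comparison. A large fall in this assay is therefore expected for compound 4 as well, with the estimated step of a 96-fold lower number from compound 1 to compound 4 (1.98 log units; beyond the scatter). The expected value for compound 4 is 0.5 nM, in the range 0.1 nM to 2.5 nM.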

Compound 4, inhibition constant: 0.159 nM
Compound 4: the middle estimate sits 3.1-fold (0.50 log units) above what was measured; the measured number falls inside the stated range.
By their numbers in this assay, from the lowest: compounds 2 and 4 (each within the scatter of the next); then compound 3; then compound 1.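

In this assay, a second aryl group on the amine nitrogen in the ring gives a large step, a 300-fold lower number from compound 1 to compound 4 (2.48 log units; beyond the scatter), so the fall seen with 2-bromophenyl is not limited to that one group. The two aryl groups themselves cannot be told apart: a 1.2-fold higher number from compound 2 to compound 4 (0.06 log units; within the scatter) lies within the scatter, even though both the halogen and its place on the phenyl ring differ between them, and so this position tolerates that double change in this assay with no measurable loss. No measured evidence accounts for the large step from methyl to aryl or for the match between the two aryl groups.

Still open is whether the halogen contributes at all, since the series shown offers no comparison with a plain phenyl on this nitrogen, and the bromine and iodine effects cannot be separated from where each sits on the ring. Going by these compounds, it is also open whether an aromatic ring is needed here, or whether a benzyl group or a longer alkyl chain on the same nitrogen would bring a similar fall from the methyl value.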